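Propoxy in place of isobutylsulfanyl: cytotoxicity expected for compound 3

A few compounds are considered here, and "the series" means these few. Any claim that something is new, unique, unknown or untested is made for them only; others in the source may bear on it.

Measured compounds:
Compound 1, `CC(C)CSc1nc(N)nc2c1ncn2/C=C1/CC1(CO)CO`, in an ADME assay on BCBL1 cells (Homo sapiens) for cytotoxicity, with a stated time of 7 days (on this read-out lower numbers stand for higher toxicity in this test and higher numbers for lower toxicity in this test), reaches only a limit, > 20000 nM.
Compound 2, `CCCSc1nc(N)nc2c1ncn2/C=C1/CC1(CO)CO`, in this assay likewise reaches only a limit, > 20000 nM.

Among the compounds with values here, compound 1 therefore stands at the limit of this assay and not at a number, and the one further value shown is also a limit. The step that the two limits leave unreadable from compound 1 to compound 2, hydrogen in place of methyl on a saturated chain carbon bound to two saturated chain carbons, gives no readable size because of the limit of > 20000 nM in this assay, at which 2 of the 2 values shown sit.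

Compound 3, `CCCOc1nc(N)nc2c1ncn2/C=C1/CC1(CO)CO`, differs from compound 1 by propoxy in place of isobutylsulfanyl on an aromatic carbon. No measured step bears on this change, since both shown values sit at the limit. The step that the limit leaves unreadable from compound 1 to compound 3 is therefore expected to be none beyond the scatter, with compound 3 most likely returning a limit as well. Compound 3 is estimated at 30000 nM, in a range from 15000 nM to 100000 nM.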

Compound 3, half-maximal cytotoxic concentration: > 20000 nM
Compound 3: no number, only a limit; the forecaster's own chance of this, stated with the estimate: 85%; the middle value lies beyond the limit too.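

Neither the step from compound 1 to compound 3 nor the step from compound 2 to compound 3 can be read, because all three results are limits and not numbers: the limit of > 20000 nM in this assay, at which 3 of the 3 values shown sit. The compounds shown leave open whether compound 1, compound 2 and compound 3 differ at all in this assay.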